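The source may report more compounds than this note shows. Statements on the series, on what has been measured and on what is new or still open speak of the compounds shown alone.

Compound 1 `O=C1NCCN1c1ccc(S(=O)(=O)Nc2ccc(F)cc2)cc1` is the point of departure. Among the compounds with values here, in a functional assay on MCF7 cells (Homo sapiens) for antiproliferative activity, read by sulforhodamine B assay, with a stated time of 48 h (on this read-out higher numbers stand for weaker inhibition and lower numbers for stronger inhibition), compound 1 gives 690 nM, the lowest of the two numbers known here; its nearest neighbour, compound 2 `CCCCOc1ccc(NS(=O)(=O)c2ccc(N3CCNC3=O)cc2)cc1`, gives 870 nM. Compound 3 `CCCCCCOc1ccc(NS(=O)(=O)c2ccc(N3CCNC3=O)cc2)cc1` reaches only the limit > 1000 nM in this assay and yields no number. The measured steps are all small: a 1.3-fold higher number from compound 1 to compound 2 (0.10 log units; within the scatter), an at least 1.4-fold higher number from compound 1 to compound 3 (0.16 log units; that floor lies within the scatter) and an at least 1.1-fold higher number from compound 2 to compound 3 (0.06 log units; that floor lies within the scatter). Compound 4 `Cc1ccccc1NS(=O)(=O)c1ccc(N2CCNC2=O)cc1` is not yet measured; it differs from compound 1 by 2-methylphenyl in place of 4-fluorophenyl on a sulfonamide nitrogen. Within the data shown here, the steps so far, each changing the group on the sulfonamide nitrogen without moving the number beyond the scatter, bear on this change and point to a step in this assay no larger than the scatter, in either direction. Compound 4 is therefore expected to give about 800 nM, between 350 nM and 2000 nM, an expected step of a 1.2-fold higher number from compound 1 to compound 4 (0.06 log units; within the scatter).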

Compound 4, half-maximal inhibitory concentration: 280 nM
For compound 4 the middle estimate is 2.9-fold (0.46 log units) above the measured one; the whole stated range lies above it.
By their numbers in this assay, from the lowest: compound 4; then compounds 1 and 2 (each within the scatter of the next). At a limit, above all of these: compound 3.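

Unlike the earlier steps, changing the group on the sulfonamide nitrogen here moves the number beyond the scatter: 2-methylphenyl in place of 4-fluorophenyl gives a 2.5-fold lower number from compound 1 to compound 4 (0.39 log units; beyond the scatter) in this assay. Both groups count the same heavy atoms and carry one six-membered aromatic ring of carbon only, so those counts do not separate them. Nothing shown here bears on why the number moves. As far as these compounds go, what 4-methylphenyl or 2-fluorophenyl would give on this nitrogen remains open, and with it whether the step goes with the methyl group or with its place on the ring.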